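The source may report more compounds than this note shows. Statements on the series, on what has been measured and on what is new or still open speak of the compounds shown alone.

Measured compounds in the series:
compound 1 `CCOC(=O)CCCCCOc1cccc(CN(C(=O)c2ccc(-c3cccnc3)cc2)C(C)C)c1` — in an ADME assay on BJ cells (Homo sapiens) for cytotoxicity, read by CellTiter-Glo and resazurin assay, with a stated time of 72 h (on this read-out higher numbers stand for an effect only at larger amounts of compound and lower numbers for an effect already at smaller amounts), compound 1 gives > 26000 nM, a limit of the assay
compound 2 `CCOC(=O)CCCCCOc1cccc(CN(C(=O)c2ccc(-c3ccco3)cc2)C(C)C)c1` — in this assay compound 2 gives > 26000 nM, a limit of the assay

Compound 2 therefore stands only at a limit in this assay, with no number behind it. Among the measured compounds shown here, the one measured step, a step that the two limits leave unreadable from compound 1 to compound 2, is unreadable because of the limit of > 26000 nM in this assay, at which 2 of the 2 values shown sit. Nothing in these two results separates the compounds.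

Compound 3 `CCOC(=O)CCCCCOc1cccc(CN(C(=O)c2ccc(-c3cccc(-c4nnc(C)o4)c3)cc2)C(C)C)c1` is the next change on the same aromatic carbon: 3-(5-methyl-1,3,4-oxadiazol-2-yl)phenyl in place of furan-2-yl on an aromatic carbon. For the measured compounds named here, the only step that bears on it is the unreadable one from compound 1 to compound 2, so no size or direction can be taken from the data for the step to compound 3 in this assay.

Compound 3 is expected at about 40000 nM, within 15000 nM to 120000 nM. The expected step that the limit leaves unreadable from compound 2 to compound 3 is thus no larger than the scatter, and most likely the assay again returns only a limit.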

Compound 3, half-maximal effective concentration: > 26000 nM
Compound 3 ended at the assay's limit; the forecaster's own chance of this, stated with the estimate: 80%; the middle value does not contradict the limit.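

Among the compounds shown here, no step among compound 1, compound 2 and compound 3 can be read in this assay, because all three results are limits of the assay and carry no number: the limit of > 26000 nM in this assay, at which 3 of the 3 values shown sit. The compounds shown leave open at what concentration any of the three has an effect, and how far apart they lie.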